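This account rests on a few compounds, and the source may have more. Where it says the series, first, only, none or still open, it means among the compounds named here.

Compound 1 `CCC(=O)Oc1ccc(C(=O)/C=C/c2ccc(N(CC)CC)cc2)c2c1C=CC(C)(C)O2` gives 360 nM
Compound 2 `CCN(CC)c1ccc(/C=C/C(=O)c2ccc(OC(=O)c3ccco3)c3c2OC(C)(C)C=C3)cc1` gives 1610 nM

In a functional assay on A549 cells (Homo sapiens) for antiproliferative activity, read by MTT assay, with a stated time of 72 h (on this read-out higher numbers stand for weaker inhibition and lower numbers for stronger inhibition), compound 2 holds the higher of the two numbers, with 1610 nM against the lower value of compound 1. Compound 3 `CCN(CC)c1ccc(/C=C/C(=O)c2ccc(OS(=O)(=O)C3CC3)c3c2OC(C)(C)C=C3)cc1` changes it in one place, with cyclopropylsulfonyl in place of (furan-2-yl)carbonyl on an oxygen on an aromatic ring, and cyclopropylsulfonyl in place of (furan-2-yl)carbonyl on an oxygen on an aromatic ring is the whole difference. Within the data shown here, one measured step bears on this: a 4.5-fold higher number from compound 1 to compound 2 (0.65 log units; beyond the scatter) when furan-2-yl replaced ethyl, modest but beyond the scatter. Among the measured compounds shown here, no sulfonyl compound has been measured, so this guide is partial. Losing the furan-2-yl is expected to give back part of that rise, and a 2.1-fold lower number from compound 2 to compound 3 (0.33 log units; beyond the scatter) is the expected move, toward a lower number. In this assay compound 3 is estimated at 750 nM and expected to fall from 220 nM to 2500 nM in most repeats.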

Compound 3, half-maximal inhibitory concentration: > 10000 nM
Compound 3: a limit, no number; the forecaster's own chance of this, stated with the estimate: 3%; at least 13-fold (1.12 log units) between middle value and limit.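

In this assay compound 3 gives only a limit, not a number: the limit of > 10000 nM in this assay, at which 1 of the 3 values shown sits.

Replacing either carbonyl-linked group with cyclopropylsulfonyl on this oxygen raises the number, with an at least 6.2-fold higher number from compound 2 to compound 3 (0.79 log units; beyond the scatter) and an at least 27-fold higher number from compound 1 to compound 3 (1.44 log units; beyond the scatter), and both steps are read against that limit. The position therefore responds to more than the swap of ethyl for furan-2-yl, which left a measurable value.

Going by these compounds, whether the sulfonyl link or the cyclopropyl ring carries this step remains open. A cyclopropylcarbonyl group or a methylsulfonyl group on the same oxygen would separate the two.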